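A Phenyl Swapped for 2-Phenylethenyl on the Shared Core

This account rests on a few compounds, and the source may have more. Where it says the series, first, only, none or still open, it means among the compounds named here.

In a functional assay on NCI-H460 cells (Homo sapiens) for antiproliferative activity, with a stated time of 72 h (a higher number here means a weaker inhibitor, a lower number a stronger inhibitor), compound 1 `Nc1ncnn2c([C@@H]3O[C@H](CO)[C@@H](O)[C@H]3O)cc(C#CC3CC3)c12` gives 80 nM, and compound 2 `Nc1ncnn2c([C@@H]3O[C@H](CO)[C@@H](O)[C@H]3O)cc(C#Cc3ccc(F)cc3)c12` gives 79400 nM. Going by the values given here, the single change that separates these two amounts to a 990-fold higher number from compound 1 to compound 2 (3.00 log units; beyond the scatter).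

Compound 3 `Nc1ncnn2c([C@@H]3O[C@H](CO)[C@@H](O)[C@H]3O)cc(-c3ccccc3)c12` has no exact number, only the limit > 100000 nM. This is the limit of > 100000 nM in this assay, at which 1 of the 3 values shown sits. Phenyl in place of 2-cyclopropylethynyl amounts to an at least 1200-fold higher number from compound 1 to compound 3 (3.09 log units; beyond the scatter), whereas phenyl in place of 2-(4-fluorophenyl)ethynyl gives an at least 1.2-fold higher number from compound 2 to compound 3 (0.10 log units; that floor lies within the scatter), a floor that lies within the scatter.

Compound 4 `Nc1ncnn2c([C@@H]3O[C@H](CO)[C@@H](O)[C@H]3O)cc(/C=C/c3ccccc3)c12` carries 2-phenylethenyl in place of phenyl on an aromatic carbon. Its group ends in an aromatic ring, as do those of compound 2 and compound 3, while compound 1 goes against this pairing with its cyclopropyl end and its far lower number. The large steps from compound 1 therefore set the expectation less than the small step between the two aryl compounds does. On that basis, no step beyond the scatter is expected, and any shift would more likely be towards a lower number: the expected result is an at least 1.6-fold lower number from compound 3 to compound 4 (0.22 log units; that floor lies within the scatter). For compound 4 the estimated value is 60000 nM, with an expected range from 8000 nM to 100000 nM.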

Compound 4, half-maximal inhibitory concentration: 3700 nM
Beside the measured number, compound 4's estimate is 16-fold (1.21 log units) above it, outside the stated range (below it).
By their numbers in this assay, from the lowest: compound 1; then compound 4; then compound 2. At a limit, above all of these: compound 3.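

At this position of the shared core, a group ending in an aromatic ring no longer goes with a number at the weak end in this assay: 2-phenylethenyl in place of phenyl gives an at least 27-fold lower number from compound 3 to compound 4 (1.43 log units; beyond the scatter), and this is only a floor, as the value of compound 3 is a limit: the limit of > 100000 nM in this assay, at which 1 of the 4 values shown sits. The two aryl-ending groups that could not be told apart earlier now also differ from the new one, since 2-phenylethenyl in place of 2-(4-fluorophenyl)ethynyl gives a 21-fold lower number from compound 2 to compound 4 (1.33 log units; beyond the scatter), which shows that what links the ring to the core, or the fluorine on it, counts here. Even so, the aryl end does not reach the cyclopropyl end, with 2-phenylethenyl in place of 2-cyclopropylethynyl giving a 46-fold higher number from compound 1 to compound 4 (1.67 log units; beyond the scatter).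

The step from compound 2 joins two changes, double bond for triple bond and loss of the fluorine, so the compounds shown cannot say which of them carries it. They also leave open where 2-phenylethynyl, with neither change made alone, or the saturated 2-phenylethyl would fall, and whether 2-cyclopropylethenyl would keep the low number of compound 1.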